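Aryl swap on an amide quinolone series in A549 cells

This account rests on a few compounds, and the source may have more. Where it says the series, first, only, none or still open, it means among the compounds named here.

Measured so far:
compound 1, `Cn1ccc2c(Oc3ccc(NC(=O)c4cn(-c5ccc(F)c(Cl)c5)c5ccccc5c4=O)cc3F)ccnc21`, 1210 nM
compound 2, `O=C(Nc1ccc(Oc2ccnc3[nH]ccc23)c(F)c1)c1cn(-c2ccc(C(F)(F)F)cc2Cl)c2ccccc2c1=O`, 1620 nM

The two compounds measured to date sit close together in a functional assay on A549 cells (Homo sapiens) for inhibition, read by MTT assay, with a stated time of 72 h; a higher number here means a weaker inhibitor, a lower number a stronger inhibitor. Compound 2 gives 1620 nM, the higher of the two numbers, while compound 1 gives 1210 nM in this assay; the gap between them lies within the usual scatter, so neither can be called the stronger inhibitor on this evidence.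

Compound 3, `O=C(Nc1ccc(Oc2ccnc3[nH]ccc23)c(F)c1)c1cn(-c2ccc(F)c(Cl)c2)c2ccccc2c1=O`, has not yet been measured. It is reached from compound 2 by a single change: 3-chloro-4-fluorophenyl in place of 2-chloro-4-(trifluoromethyl)phenyl on an aromatic nitrogen. Within the data shown here, no step between two measured compounds matches this change, so there is nothing to say how large its effect might be.

With both measured numbers falling within scatter of each other, the expectation for compound 3 is a step from compound 2 that stays within the scatter, with no clear direction, that is a 1.2-fold lower number from compound 2 to compound 3 (0.10 log units; within the scatter). On this basis compound 3 is estimated at 1300 nM in this assay, within a range from 500 nM to 3500 nM.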

Compound 3, half-maximal inhibitory concentration: 2150 nM
The estimate for compound 3 lay 1.7-fold (0.22 log units) below the measured number; the measured number falls inside the stated range.
By their numbers in this assay, from the lowest: compounds 1, 2 and 3 (each within the scatter of the next).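

In this assay, 3-chloro-4-fluorophenyl in place of 2-chloro-4-(trifluoromethyl)phenyl on the aromatic nitrogen gives a 1.3-fold higher number from compound 2 to compound 3 (0.12 log units; within the scatter), so the two aryl groups cannot be told apart at this position, although they differ in their count of heavy atoms. Compound 3 also links compound 1 and compound 2, which differ in two places, and it isolates hydrogen in place of methyl on the other aromatic nitrogen as a 1.8-fold higher number from compound 1 to compound 3 (0.25 log units; within the scatter), so neither single change has a readable effect here. Nothing among the data shown bears on why these numbers lie so close together.

From the compounds shown here alone, all three compounds carry a phenyl ring with chlorine and fluorine on the first nitrogen, so it remains open whether a pyridine ring, a benzyl group or a small alkyl chain there would give a step beyond the scatter. Going by these compounds, it also remains open whether an amine-bearing chain on the second nitrogen would do so, and whether any of these steps would look the same outside this assay.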